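The source may report more compounds than this note shows. Statements on the series, on what has been measured and on what is new or still open speak of the compounds shown alone.

Measured compounds in an assay on isolated protein for displacement of a labelled ligand from metabotropic glutamate receptor 5 (Homo sapiens), with a stated time of 60 min, tested at 1 uM; on this read-out lower numbers stand for less inhibition and higher numbers for more inhibition at the one concentration tested (going by the name of the read-out):

Compound 1 `COc1ccc(S(=O)(=O)c2cnc3ccc(C)cc3c2N2CCC(C)CC2)cc1` gives 62% in this assay.
Compound 2 `COc1ccc(S(=O)(=O)c2cnc3ccc(C)cc3c2N2CCC(C)CC2)cc1Cl` gives 93% in this assay.
Compound 3 `CC1CCN(c2c(S(=O)(=O)c3cccc(Cl)c3)cnc3cc(Cl)ccc23)CC1` gives 92% in this assay.

Compound 4 `CC1CCN(c2c(S(=O)(=O)c3ccccc3)cnc3cc(Cl)ccc23)CC1` is still to be measured. It differs from compound 3 by hydrogen in place of chloro on an aromatic carbon. The same kind of change separates compound 2 from compound 1: hydrogen in place of chloro on an aromatic carbon. The two places are not identical: in compound 2 the chloro that leaves stands ortho to a methoxy group and meta to a large group, whereas in compound 3 it stands meta to a large group only, with no methoxy group on that ring. The two changes are therefore the same kind of change, not the same change. How the core of compound 3 differs from the core of compound 2 is not broken down here; compound 3 and compound 2 give numbers within the scatter of each other, so nothing is said about their order.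

Among the compounds with values here, the one measured instance of this kind of change reads a number 31 percentage points lower from compound 2 to compound 1 (beyond the scatter). The step from compound 3 to compound 4 is expected to run in the same direction but more modestly, a number 27 percentage points lower from compound 3 to compound 4 (beyond the scatter), since the ring of compound 3 carries no methoxy group. Within the data shown here, compound 4 is expected to give 65%, within 40% to 85%, because compound 3 gives 92% and the only precedent is the step of a number 31 percentage points lower from compound 2 to compound 1 (beyond the scatter).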

Compound 4, a percentage reported as inhibition, at one concentration (the size of the read-out at that concentration, not a potency): 93%
Compound 4: the middle estimate sits 28 percentage points below what was measured; measured number above the stated range.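

In this assay, the change from chloro to hydrogen on an aromatic carbon does not carry over from one core to the other as a fixed step: the same change on two cores in this assay, a number 31 percentage points lower (beyond the scatter) from compound 2 to compound 1 and a number 1 percentage points higher (within the scatter) from compound 3 to compound 4, 32 percentage points apart, beyond the scatter of two such steps

On the core of compound 3, the 3-chlorophenyl to phenyl change reads a number 1 percentage points higher from compound 3 to compound 4 (within the scatter), so the chloro on that ring cannot be shown to matter in this assay, whereas the same kind of change on the methoxy-bearing ring of compound 2 is a large step. Within the data shown here, this does not show which feature separates the two cases, since compound 2 and compound 3 differ in more than one place, and the methoxy group and the rest of the core cannot be told apart with only two pairs; the read-out also gives only the size of inhibition at one concentration, so it does not show how compound 3 and compound 4 would compare at any other concentration.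

Still open, on these data alone, is how the step would read on the core of compound 3 with a methoxy group added to the phenyl ring, which would test that group directly. Also open, as far as these compounds go, is how this assay would respond on either core to a fluoro, a trifluoromethyl, an amine or a carboxylic acid in the place of the chloro.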